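Replacing 4-chlorophenyl with ethoxy on a carbonyl carbon

The source may hold more compounds than are shown below. What is called first, only, known or untested is meant among the compounds shown, and "the series" means these compounds.

In a functional assay on HepG2 cells (Homo sapiens) for cytotoxicity, read by MTT assay, with a stated time of 48 h (on this read-out higher numbers stand for weaker inhibition and lower numbers for stronger inhibition), compound 3 `O=C(CSCc1nc2cc([N+](=O)[O-])ccc2[nH]1)c1ccc(Cl)cc1` gives 2650 nM, within the usual scatter of compound 1 `O=[N+]([O-])c1ccc2[nH]c(CSCc3nc4cc([N+](=O)[O-])ccc4[nH]3)nc2c1` at 2250 nM, while compound 2 `O=C(CSCc1nc2cc([N+](=O)[O-])ccc2[nH]1)c1ccccc1` sits clearly higher at 16100 nM. Compound 4 `CCOC(=O)CSCc1nc2cc([N+](=O)[O-])ccc2[nH]1` has ethoxy in place of 4-chlorophenyl on a carbonyl carbon. Among the compounds with values here, the one measured step that bears on this change is modest: a 6.1-fold lower number from compound 2 to compound 3 (0.78 log units; beyond the scatter), with chloro in place of hydrogen on an aromatic carbon. Within the data shown here, no measured compound carries ethoxy, so the guide is weak, but with the whole 4-chlorophenyl gone, a modest move back towards higher numbers in this assay is expected. The expected step is a 3.8-fold higher number from compound 3 to compound 4 (0.58 log units; beyond the scatter). Compound 4 is estimated at 10000 nM, with an expected range from 3500 nM to 30000 nM.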

Compound 4, half-maximal inhibitory concentration: > 100000 nM
Compound 4: only a limit was reported; the forecaster's own chance of this, stated with the estimate: 5%; middle value at least 10-fold (1.00 log units) from the limit.
By their numbers in this assay, from the lowest: compounds 1 and 3 (each within the scatter of the next); then compound 2. At a limit, above all of these: compound 4.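

In this assay, compound 4 gives only a limit and not a number: the limit of > 100000 nM in this assay, at which 1 of the 4 values shown sits. Ethoxy in place of 4-chlorophenyl on a carbonyl carbon gives an at least 37-fold higher number from compound 3 to compound 4 (1.57 log units; beyond the scatter), and ethoxy in place of phenyl gives an at least 6.2-fold higher number from compound 2 to compound 4 (0.79 log units; beyond the scatter). Whereas the earlier compounds showed only the effect of chloro on the ring, these steps show that the number also rises sharply when the whole ring leaves this position, even relative to plain phenyl.

The compounds shown leave open whether the rise follows the loss of the ring or the arrival of the ethoxy oxygen. A methyl group or a phenoxy group on the same carbonyl carbon would separate the two.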